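The source may hold more compounds than are shown below. What is called first, only, known or untested is meant among the compounds shown, and "the series" means these compounds.

Of the compounds shown here, three of one shared core have been measured, and a fourth awaits a number. In a functional assay on HeLa cells (Homo sapiens) for cytotoxicity, read by MTT assay, with a stated time of 48 h (on this read-out lower numbers stand for stronger inhibition and higher numbers for weaker inhibition), compound 3 `CC(C)(C)c1ccc(Cn2cc(COc3ccc4c(=O)ccoc4c3)nn2)cc1` gives 17600 nM, the higher of the two plain numbers shown. Compound 2 `O=c1ccoc2cc(OCc3cn(Cc4cccc(F)c4)nn3)ccc12` gives 7550 nM in this assay. Compound 1 `Cc1ccc(Cn2cc(COc3ccc4c(=O)ccoc4c3)nn2)cc1` reaches only a limit of this assay, > 100000 nM. Compound 4 `O=c1ccoc2cc(OCc3cn(Cc4ccccc4)nn3)ccc12` differs from compound 3 by hydrogen in place of tert-butyl on an aromatic carbon. The measured step that touches this position is an at least 5.6-fold lower number from compound 1 to compound 3 (0.75 log units; beyond the scatter), where a larger group brought a lower number; the step of an at least 13-fold lower number from compound 1 to compound 2 (1.12 log units; beyond the scatter) alters a different part. Taking the group away entirely is expected to move the number the opposite way, so a step of a 3.4-fold higher number from compound 3 to compound 4 (0.53 log units; beyond the scatter) is estimated. Compound 4 is therefore expected to give about 60000 nM, likely between 15000 nM and 200000 nM, in this assay.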

Compound 4, half-maximal inhibitory concentration: > 100000 nM
Compound 4: a limit, no number (the forecaster's own chance of this, stated with the estimate: 35%); middle value at least 1.6-fold (0.22 log units) from the limit.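

With hydrogen on this aromatic carbon, the number leaves the readable range, giving an at least 5.6-fold higher number from compound 3 to compound 4 (0.75 log units; beyond the scatter) and an at least 13-fold higher number from compound 2 to compound 4 (1.12 log units; beyond the scatter). A group on this ring can therefore matter in this assay, but not every group does: compound 1, with methyl, also gives no plain number, so hydrogen and methyl cannot be told apart here. The step between compound 1 and compound 4 cannot be read because both stand at the same limit: the limit of > 100000 nM in this assay, at which 2 of the 4 values shown sit.

As far as these compounds go, whether an amine or a carboxylic acid in this place would give a readable number stays open.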